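Amide replacement on the shared core: solubility notes

The source may hold more compounds than are shown below. What is called first, only, known or untested is meant among the compounds shown, and "the series" means these compounds.

Measured in a physicochemical assay for solubility, read by HPLC; on this read-out higher numbers stand for higher solubility and lower numbers for lower solubility: compound 1 `O=C(c1ccccc1Cl)N1CCN(c2nc(=O)c3cc(C(F)(F)F)cc([N+](=O)[O-])c3s2)CC1` gives 8.18 ug/mL; compound 2 `O=C(c1cccc(F)c1)N1CCN(c2nc(=O)c3cc(C(F)(F)F)cc([N+](=O)[O-])c3s2)CC1` gives 0.2 ug/mL.

Among the measured compounds shown here, compound 2 stands lowest of the two numbers; the only measured step, a 41-fold lower number from compound 1 to compound 2 (1.61 log units; beyond the scatter), shows that the group on the carbonyl carbon moves this assay a great deal. Compound 3 `O=C(C1CCC1)N1CCN(c2nc(=O)c3cc(C(F)(F)F)cc([N+](=O)[O-])c3s2)CC1` carries cyclobutyl in place of 3-fluorophenyl on a carbonyl carbon. For the measured compounds named here, no measured step covers an aryl-to-cycloalkyl exchange, so the direction rests on the size seen for the one amide change. For compound 3 a rise is expected, a 10-fold higher number from compound 2 to compound 3 (1.00 log units; beyond the scatter), giving an estimate of 2 ug/mL with a range of 0.3 ug/mL to 15 ug/mL.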

Compound 3, solubility: 39.3 ug/mL
Beside the measured number, compound 3's estimate is 20-fold (1.29 log units) below it, and the stated range ends below it.
By their numbers in this assay, from the lowest: compound 2; then compound 1; then compound 3.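

In this assay the cyclobutyl amide gives a 200-fold higher number from compound 2 to compound 3 (2.29 log units; beyond the scatter) and also a 4.8-fold higher number from compound 1 to compound 3 (0.68 log units; beyond the scatter) on the same core, so this carbonyl position can carry a non-aromatic ring and reach a number above both aryl amides. Among the compounds shown here, the highest number in the set thus belongs to the only group without an aromatic ring, a pattern resting on compound 3 alone. No evidence on hand bears on what drives these steps. Still open, on these data alone, is whether a longer open chain behaves like cyclobutyl on this carbonyl carbon. Also open, as far as these compounds go, is what an amine or a carboxylic acid on that ring would do.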